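The compounds below may be only part of what the source reports. "The series", "measured", "known", "first", "only" and "open" are said of these compounds alone.

For the measured compounds named here, compound 1 `O=c1ccoc2cc(OCc3cn(Cc4ccc([N+](=O)[O-])cc4)nn3)ccc12` stands, on the numbers so far, only at a limit: in a functional assay on A549 cells (Homo sapiens) for cytotoxicity, read by MTT assay, with a stated time of 48 h (on this read-out lower numbers stand for stronger inhibition and higher numbers for weaker inhibition), compound 1 gives > 100000 nM, which is a limit of the assay and not a number. Compound 2 `O=c1ccoc2cc(OCc3cn(Cc4cccc(Br)c4)nn3)ccc12` likewise sits at a limit in this assay, where compound 2 gives > 100000 nM. Going by the values given here, compound 3 `O=c1ccoc2cc(OCc3cn(Cc4cccc([N+](=O)[O-])c4)nn3)ccc12` is the one member with a number, giving 9450 nM in this assay. The step of an at least 10-fold lower number from compound 1 to compound 3 (1.02 log units; beyond the scatter) is large and beyond the scatter, and so is an at least 10-fold lower number from compound 2 to compound 3 (1.02 log units; beyond the scatter); the step that the two limits leave unreadable from compound 1 to compound 2 cannot be sized, since both ends sit at the limit of > 100000 nM in this assay, at which 2 of the 3 values shown sit.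

Compound 4 `O=c1ccoc2cc(OCc3cn(Cc4cccc(Cl)c4)nn3)ccc12` is not yet measured. It differs from compound 1 by 3-chlorophenyl in place of 4-nitrophenyl on a saturated chain carbon bound to an aromatic nitrogen. The measured step closest to this change is a step that the two limits leave unreadable from compound 1 to compound 2, where a 3-bromophenyl on the same saturated chain carbon left the value at the limit of > 100000 nM in this assay, at which 2 of the 3 values shown sit; among the three measured compounds only a nitro on this ring, in compound 3, has produced a number. Compound 4 is therefore expected to remain at or near the limit, with the estimated step of a number no higher from compound 1 to compound 4 (the limit leaves the size open) being none beyond the scatter. For compound 4 the expected value in this assay is 100000 nM, within a range from 40000 nM to 300000 nM.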

Compound 4, half-maximal inhibitory concentration: 13700 nM
Compound 4: middle estimate off by 7.3-fold (0.86 log units), on the high side, and the stated range ends above it.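

In this assay, the 3-chlorophenyl group on a saturated chain carbon bound to an aromatic nitrogen gives a readable number, with an at least 7.2-fold lower number from compound 1 to compound 4 (0.86 log units; beyond the scatter) and an at least 7.2-fold lower number from compound 2 to compound 4 (0.86 log units; beyond the scatter), so a halogen on this ring does not by itself leave a compound at the limit. Chloro in place of nitro on an aromatic carbon gives a 1.4-fold higher number from compound 3 to compound 4 (0.16 log units; within the scatter), which leaves compound 3 and compound 4 not separable and shows that a nitro is not needed for a readable number. Compound 2 goes against any simple reading of halogens on this ring, since its 3-bromophenyl group gives no number while the 3-chlorophenyl group of compound 4 does, and the step from compound 1 to compound 2 still cannot be read, as both ends are limits: the limit of > 100000 nM in this assay, at which 2 of the 4 values shown sit.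

Going by these compounds, what separates chloro from bromo here stays open, since two halogens on one ring offer no trend. Also open, on these data alone, is how this assay would read for an amine or a carboxylic acid on the phenyl ring, or for a longer chain in place of the saturated chain carbon.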